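Replacing fluoro with cyano in compound 3

The source may report more compounds than this note shows. Statements on the series, on what has been measured and on what is new or still open speak of the compounds shown alone.

Compound 1 `COC[C@H](Oc1ncnc2c1cnn2-c1ncccc1Cl)C(=O)Nc1ccc(C)cn1`: > 5 h (a limit)
Compound 2 `CC(C)OC[C@H](Oc1ncnc2c1cnn2-c1ncccc1Cl)C(=O)Nc1ccc(Cl)cn1`: 0.233 h
Compound 3 `CC(C)OC[C@H](Oc1ncnc2c1cnn2-c1ncccc1Cl)C(=O)Nc1ccc(F)cn1`: 0.117 h

In an ADME assay on a cell-free system (plasma, Rattus norvegicus) for metabolic stability (a lower number here means that the compound disappears faster, a higher number that the compound lasts longer), compound 3 gives 0.117 h and compound 2 gives 0.233 h with a 2.0-fold lower number from compound 2 to compound 3 (0.30 log units; within the scatter) between them. The two half-lives therefore cannot be told apart on these data. For compound 1 this assay gives only a limit, > 5 h and no number.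

Compound 4 `CC(C)OC[C@H](Oc1ncnc2c1cnn2-c1ncccc1Cl)C(=O)Nc1ccc(C#N)cn1` carries cyano in place of fluoro on an aromatic carbon, para to a large group, a difference that reads cyano in place of fluoro on an aromatic carbon and leaves the rest of compound 3 unchanged. For the measured compounds named here, only one measured exchange bears on this place, the step involving compound 2 and compound 3, which amounts to a 2.0-fold lower number from compound 2 to compound 3 (0.30 log units; within the scatter) in the same read-out. With that single step inside the scatter, there is no measured direction to carry over to cyano, and no shift beyond the scatter is expected in this assay here. The expected step is a 1.0-fold higher number from compound 3 to compound 4 (0.01 log units; within the scatter) on this reasoning. The estimated half-life for compound 4 is 0.12 h with an expected range from 0.04 h to 0.4 h in this read-out.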

Compound 4, half-life: 0.367 h
Estimate against measurement, compound 4: 3.1-fold (0.49 log units) below; low and high end bracket the measured number.
By their numbers in this assay, from the lowest: compounds 3, 2 and 4 (each within the scatter of the next, the first and the last beyond it). At a limit, above all of these: compound 1.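

In this assay, for the compounds shown here, this aromatic carbon, two atoms from the ring nitrogen, now proves responsive to the group it carries: cyano in place of fluoro gives a 3.1-fold higher number from compound 3 to compound 4 (0.50 log units; beyond the scatter), the first step at this place that lies beyond the scatter. Cyano in place of chloro gives a 1.6-fold higher number from compound 2 to compound 4 (0.20 log units; within the scatter), so the exchange registers only against fluoro, and the chloro compound cannot be separated from either of the other two. Nothing in the evidence shown bears on why the number moves at this place.

On these data alone, whether an amine, a carboxylic acid or a trifluoromethyl group on this carbon would move the half-life further stays open, as does whether the step from fluoro to cyano would hold with a different ether chain on the other side of the amide. Compound 1, whose > 5 h is a limit and not a number, differs from the other compounds in more than one place, so what sets it apart from them cannot be assigned to either change.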